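The compounds below may be only part of what the source reports. "The series", "measured", "known", "first", "only" and "open" are said of these compounds alone.

Series notes. Compound 1 `Cc1cc(Nc2cc(-c3ccccc3)[nH]n2)n2nc(SCc3ccc(Cl)cc3)nc2n1` carries 4-chlorobenzyl on the shared core; in a functional assay on MGC-803 cells (Homo sapiens) for inhibition, read by MTT assay, with a stated time of 72 h (a lower number here means a stronger inhibitor, a higher number a weaker inhibitor), compound 1 gives 3950 nM. Compound 2 `CCCCCc1c(C)nc2nc(SCc3ccc(Cl)cc3)nn2c1Nc1cc(-c2ccccc2)[nH]n1` differs from compound 1 by pentyl in place of hydrogen on an aromatic carbon; compound 2 gives 7140 nM, a move of a 1.8-fold higher number from compound 1 to compound 2 (0.26 log units; within the scatter). Compound 3 `Cc1cc(Nc2ccn(Cc3nc(C)c4ccccc4n3)n2)n2nc(SCc3ccc(Br)cc3)nc2n1` differs from compound 1 in more than one place; compound 3 gives 960 nM. Of the three numbers, compound 1 stands second highest, close to compound 2 and clearly above compound 3.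

Compound 4 `Cc1cc(Nc2cc(-c3ccccc3)[nH]n2)n2nc(SCc3cccc4ccccc34)nc2n1` is the next entry: naphthalen-1-yl in place of 4-chlorophenyl on a saturated chain carbon bound to a sulfur. Within the data shown here, no measured step touches the aryl group on the saturated chain carbon bound to a sulfur; the only single-point step, from compound 1 to compound 2, lies elsewhere and stays within the scatter, so it gives no direction. Compound 3 carries a changed halogen on that aryl group, but it differs from compound 1 in a second place as well, so the pair cannot be read as one step. The expectation for compound 4 in this assay is therefore a step of about a 1.1-fold lower number from compound 1 to compound 4 (0.05 log units; within the scatter), with no direction beyond the scatter claimed. Compound 4 is estimated at 3500 nM, in a range from 1200 nM to 10000 nM.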

Compound 4, half-maximal inhibitory concentration: 3120 nM
Beside the measured number, compound 4's estimate is 1.1-fold (0.05 log units) above it; the range from low to high includes it.
By their numbers in this assay, from the lowest: compound 3; then compounds 4, 1 and 2 (each within the scatter of the next, the first and the last beyond it).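

In this assay, among these compounds, the change at the saturated chain carbon bound to a sulfur gives a 1.3-fold lower number from compound 1 to compound 4 (0.10 log units; within the scatter), the first single-place reading on the aryl group there. Naphthalen-1-yl brings two six-membered aromatic rings of carbon only where 4-chlorophenyl brought one and removes the chlorine, yet the step stays within the scatter, so this one exchange leaves the number without a readable change. Nothing available accounts for this outcome, and no explanation of it can be offered from the data in hand.

What the compounds shown leave open is whether a group of another kind on the same saturated chain carbon bound to a sulfur, such as an amine, a carboxylic acid or a longer alkyl chain, would produce a step beyond the scatter. Compound 3 gives 960 nM, but it differs from compound 1 in more than one place, so the contribution of its bromine-bearing aryl group cannot be separated from that of its other change.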